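The source may report more compounds than this note shows. Statements on the series, on what has been measured and on what is new or still open speak of the compounds shown alone.

This account follows three measured compounds and one that awaits measurement, all tested in an assay on CHO cells for displacement of a labelled ligand from corticotropin-releasing factor receptor 1 (Homo sapiens); on this read-out higher numbers stand for weaker inhibition and lower numbers for stronger inhibition. Compound 1 `COc1ccc(N2CCc3c(-n4ccc(N5CCNC5=O)n4)cc(C)nc32)c(C(F)F)c1` gives 56.2 nM in this assay. Compound 2 `COc1ccc(N2CCc3c(-n4ccc(N5CCN(C)C5=O)n4)cc(C)nc32)c(C)c1` gives 794 nM, and compound 3 `Cc1cc(-n2ccc(N3CCNC3=O)n2)c2c(n1)N(c1ccc(OC(C)C)cc1C)CC2` gives 1230 nM. Among these three numbers compound 2 holds the second highest place; its nearest neighbour is compound 3, whose number lies within the usual scatter of repeated measurements, so nothing can be said about an order between those two, while compound 1 lies far lower, well beyond the scatter.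

Compound 4 `COc1ccc(N2CCc3c(-n4ccc(N5CCOC5=O)n4)cc(C)nc32)c(C)c1` is the compound yet to be measured. It differs from compound 2 in a single place: 2-oxo-1,3-oxazolidin-3-yl in place of 3-methyl-2-oxoimidazolidin-1-yl on an aromatic carbon. The 2-oxo-1,3-oxazolidin-3-yl group that enters carries one hydrogen-bond acceptor more and one heavy atom fewer than the 3-methyl-2-oxoimidazolidin-1-yl group that leaves, and sits on the same aromatic carbon of the five-membered aromatic ring.

Going by the values given here, no measured pair in this set shows this exchange, so there is no step to lean on. The step expected, a 1.2-fold lower number from compound 2 to compound 4 (0.09 log units; within the scatter), is taken to be small, in no firm direction, and likely within the scatter. Compound 4 is therefore expected to give about 650 nM in this assay, with a range from 220 nM to 2000 nM.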

Compound 4, half-maximal inhibitory concentration: 1950 nM
Beside the measured number, compound 4's estimate is 3.0-fold (0.48 log units) below it; low and high end bracket the measured number.
By their numbers in this assay, from the lowest: compound 1; then compounds 2, 3 and 4 (each within the scatter of the next, the first and the last beyond it).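

In this assay, going by these compounds alone, the exchange of 3-methyl-2-oxoimidazolidin-1-yl for 2-oxo-1,3-oxazolidin-3-yl gives a 2.5-fold higher number from compound 2 to compound 4 (0.39 log units; beyond the scatter) and so provides the first comparison in this set that isolates a single place. The step is modest but beyond the scatter, which shows that inhibition at this aromatic carbon of the five-membered aromatic ring responds to a change within the attached five-membered ring, even though the group that enters has one heavy atom fewer and one hydrogen-bond acceptor more and keeps the carbonyl-bearing ring form. The data give the size and direction of this step but offer no measured explanation for it.

The compounds shown leave open whether the same exchange would give a similar step on the core of compound 1, which carries difluoromethyl rather than methyl on its aryl ring. They also leave open how inhibition would respond to a six-membered lactam such as piperidin-2-one, or to an open-chain acetamide, on the same aromatic carbon.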